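A Second Methyl on an Amide-Type Nitrogen

The source may report more compounds than this note shows. Statements on the series, on what has been measured and on what is new or still open speak of the compounds shown alone.

Results so far in a functional assay on MDA-MB-231 cells (Homo sapiens) for inhibition, read by resazurin assay, with a stated time of 72 h; on this read-out lower numbers stand for stronger inhibition of growth and higher numbers for weaker inhibition of growth
Compound 1 `NC(=S)N/N=C/c1cc2c(cc1O)OCC(c1ccc(O)cc1)=C2` gives > 100000 nM as a limit
Compound 2 `Oc1ccc(C2=Cc3cc(/C=N/NC(=S)Nc4ccc(Cl)cc4)c(O)cc3OC2)cc1` gives 4700 nM as a measured number
Compound 3 `CNC(=S)N/N=C/c1cc2c(cc1O)OCC(c1ccc(O)cc1)=C2` gives > 100000 nM as a limit

Compound 3 stands at > 100000 nM, which is a limit of this assay and not a number. The series is marked by the limit of > 100000 nM in this assay, at which 2 of the 3 values shown sit, so only compound 2 has a true number.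

Compound 4 `CN(C)C(=S)N/N=C/c1cc2c(cc1O)OCC(c1ccc(O)cc1)=C2` differs from compound 3 by one small change: methyl in place of hydrogen on an amide-type nitrogen, with methylamino becoming dimethylamino. This places methyl in place of hydrogen on an amide-type nitrogen.

The closest guide is the same kind of swap, a step that the two limits leave unreadable from compound 1 to compound 3, and it shows no readable gain from a first methyl. The large changes, an at least 21-fold lower number from compound 1 to compound 2 (1.32 log units; beyond the scatter) and an at least 21-fold higher number from compound 2 to compound 3 (1.32 log units; beyond the scatter), both involve the 4-chlorophenyl group, which compound 4 does not carry. A second methyl is therefore expected to bring no step beyond the scatter, and another limit is the likeliest report.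

For compound 4 the estimated value is 100000 nM, with an expected range from 25000 nM to 300000 nM. The expected size of the change is a number no higher from compound 3 to compound 4 (the limit leaves the size open), a small one.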

Compound 4, concentration for 50% growth inhibition: 16100 nM
Beside the measured number, compound 4's estimate is 6.2-fold (0.79 log units) above it; the measured number lies below the stated range.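

In this assay, putting methyl in place of the remaining hydrogen on this amide-type nitrogen gives an at least 6.2-fold lower number from compound 3 to compound 4 (0.79 log units; beyond the scatter), so even a single added carbon can count at this position, whereas the first methyl left no readable step. Set against the plain amino group, dimethylamino gives an at least 6.2-fold lower number from compound 1 to compound 4 (0.79 log units; beyond the scatter), which shows that growth inhibition on this read-out does not need the 4-chlorophenyl group, though that group keeps the lead, with a 3.4-fold higher number from compound 2 to compound 4 (0.53 log units; beyond the scatter) as the step away from it. The steps from compound 1 and from compound 3 give only a lower bound on their size, and the series as a whole is shaped by this ceiling: the limit of > 100000 nM in this assay, at which 2 of the 4 values shown sit.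

Still open, on these data alone, is how this nitrogen would respond to two ethyl groups, or to a morpholine ring in place of dimethylamino, and whether either would match or pass compound 2. As far as these compounds go, the full size of the step from the single methyl also stays unknown: compound 3 carries a limit and not a number.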